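The compounds below may be only part of what the source reports. "The series", "measured", "known", "first", "only" and "open" are said of these compounds alone.

Compound 2 `O=C1c2ccccc2C(=O)N1C/C=C\Cn1cc(C#CCCc2ccccc2)c(=O)[nH]c1=O` carries a phenyl group on its chain and a double bond drawn Z. In a functional assay on HeLa cells (Homo sapiens) for antiproliferative activity, read by MTT assay, with a stated time of 3 days (a higher number here means a weaker inhibitor, a lower number a stronger inhibitor), compound 2 gives only a limit, > 100000 nM, not a number. Compound 1 `CCCCC#Cc1cn(C/C=C\CN2C(=O)c3ccccc3C2=O)c(=O)[nH]c1=O` differs by ethyl in place of phenyl on a saturated chain carbon, two bonds along the chain from a triple-bonded carbon and gives 33000 nM in this assay, a step of an at least 3.0-fold lower number from compound 2 to compound 1 (0.48 log units; beyond the scatter). Compound 3 `O=C1c2ccccc2C(=O)N1C/C=C/Cn1cc(C#CCCc2ccccc2)c(=O)[nH]c1=O` keeps the phenyl group but differs from compound 2 in that (the two compounds have the same atoms and bonds and differ only in configuration as drawn: 1 of 1 stereo elements differ; a double bond is drawn Z in compound 2 and E in compound 3); compound 3 gives 29000 nM, a step of an at least 3.4-fold lower number from compound 2 to compound 3 (0.53 log units; beyond the scatter). Compound 4 `CCCCC#Cc1cn(C/C=C/CN2C(=O)c3ccccc3C2=O)c(=O)[nH]c1=O` differs from compound 3 by ethyl in place of phenyl on a saturated chain carbon, two bonds along the chain from a triple-bonded carbon, the same change that turned compound 2 into compound 1. As far as these compounds go, because the earlier step was an at least 3.0-fold lower number from compound 2 to compound 1 (0.48 log units; beyond the scatter) starting from a limit, its full size is unknown. For compound 4 a somewhat smaller step is expected, a 1.9-fold lower number from compound 3 to compound 4 (0.29 log units; within the scatter). Compound 4 is therefore estimated at 15000 nM, most likely between 5000 nM and 45000 nM.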

Compound 4, half-maximal inhibitory concentration: 89000 nM
Compound 4: middle estimate off by 5.9-fold (0.77 log units), on the low side; the measured number lies above the stated range.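

The change from phenyl to ethyl does not carry from one core to the other in this series, and on the E double bond it gives a 3.1-fold higher number from compound 3 to compound 4 (0.49 log units; beyond the scatter), reversing direction: the same change on two cores in this assay, an at least 3.0-fold lower number (0.48 log units; beyond the scatter) from compound 2 to compound 1 and a 3.1-fold higher number (0.49 log units; beyond the scatter) from compound 3 to compound 4, at least 9.2-fold (0.96 log units) apart, beyond the scatter of two such steps

The double bond tells the same story from the other side, with a 2.7-fold higher number from compound 1 to compound 4 (0.43 log units; beyond the scatter) for the ethyl pair but an at least 3.4-fold lower number from compound 2 to compound 3 (0.53 log units; beyond the scatter) for the phenyl pair.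

Compound 2 gives only a limit of the assay, > 100000 nM, so the full size of the gap stays unknown, and these four compounds do not show why the direction turns.

Still open, as far as these compounds go, is how an amine or a cyclohexyl group in place of phenyl would behave on each double-bond form in this assay. Whether either would follow the phenyl pair or the ethyl pair also remains unanswered.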